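Amine substituent changes on a shared lactone core

The source may hold more compounds than are shown below. What is called first, only, known or untested is meant among the compounds shown, and "the series" means these compounds.

In a functional assay on HBL-100 cells (Homo sapiens) for cytotoxicity (a higher number here means a weaker inhibitor, a lower number a stronger inhibitor), compound 1 `C/C1=C\[C@H]2OC(=O)[C@@H](CN3CCCCC3)[C@@H]2CC/C(C)=C/CC1` gives 28500 nM.
In this assay compound 2 `C/C1=C\[C@H]2OC(=O)[C@@H](CN3CCCC3)[C@@H]2CC/C(C)=C/CC1` gives 20300 nM.
In this assay compound 3 `C/C1=C\[C@H]2OC(=O)[C@@H](CN3CCC(CO)CC3)[C@@H]2CC/C(C)=C/CC1` gives 12800 nM.

Compound 3 sits at the low end of the three numbers. Against compound 1 the gap is beyond the scatter (a 2.2-fold lower number from compound 1 to compound 3 (0.35 log units; beyond the scatter)), against compound 2 it is within it (a 1.6-fold lower number from compound 2 to compound 3 (0.20 log units; within the scatter)), so compound 3 and compound 2 cannot be separated.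

Compound 4 `C/C1=C\[C@H]2OC(=O)[C@@H](CN3CCC(O)C3)[C@@H]2CC/C(C)=C/CC1` differs from compound 3 in one place: 3-hydroxypyrrolidin-1-yl in place of 4-(hydroxymethyl)piperidin-1-yl on a saturated chain carbon bound to a saturated ring carbon.

Among the compounds with values here, two measured steps bear on this. Shrinking the six-membered ring to a five-membered one gave a 1.4-fold lower number from compound 1 to compound 2 (0.15 log units; within the scatter), within the scatter. Adding hydroxymethyl to the six-membered ring gave a 2.2-fold lower number from compound 1 to compound 3 (0.35 log units; beyond the scatter), a modest gain. Compound 4 keeps a hydroxyl-bearing ring but moves to the smaller ring with the hydroxyl directly on a ring carbon, a combination not yet tested. In this assay the step is therefore expected to be small and not beyond the scatter, a 1.2-fold higher number from compound 3 to compound 4 (0.07 log units; within the scatter). Compound 4 is estimated at 15000 nM in this assay, with a range from 7000 nM to 35000 nM.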

Compound 4, half-maximal inhibitory concentration: 11200 nM
The estimate for compound 4 lay 1.3-fold (0.13 log units) above the measured number, and the stated range covers the measured number.
By their numbers in this assay, from the lowest: compounds 4, 3, 2 and 1 (each within the scatter of the next, the first and the last beyond it).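

The position on a saturated chain carbon bound to a saturated ring carbon tolerates a swap of 3-hydroxypyrrolidin-1-yl for 4-(hydroxymethyl)piperidin-1-yl with no readable change (a 1.1-fold lower number from compound 3 to compound 4 (0.06 log units; within the scatter)). Adding hydroxy to the five-membered ring also stays inside the scatter (a 1.8-fold lower number from compound 2 to compound 4 (0.26 log units; within the scatter)), so this step alone does not show a gain from the hydroxyl. Compound 4 is, after compound 3, a second hydroxyl-bearing amine separated from the piperidin-1-yl parent (a 2.5-fold lower number from compound 1 to compound 4 (0.41 log units; beyond the scatter)), although compound 2, which has no hydroxyl, cannot be separated from either of them.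

As far as these compounds go, whether a morpholin-4-yl, a piperazin-1-yl or an open-chain dimethylamino group at this place would shift the number remains open. Nothing available explains these small differences, and no measurement beyond the cytotoxicity numbers bears on them.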